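The compounds below may be only part of what the source reports. "The series", "measured", "known", "first", "only" and "open" are said of these compounds alone.

Compound 1 `O=C(Nc1ccc(Oc2ccnc3[nH]ccc23)c(F)c1)c1cc2cccnc2n(-c2ccccc2)c1=O`: 190 nM
Compound 2 `O=C(Nc1ccc(Oc2ccnc3[nH]ccc23)c(F)c1)c1cc2cccnc2n(-c2ccc(F)cc2)c1=O`: 62 nM

In a functional assay on A549 cells (Homo sapiens) for antiproliferative activity, read by MTT assay, with a stated time of 72 h (on this read-out lower numbers stand for stronger inhibition and higher numbers for weaker inhibition), compound 2 stands at the lower of the two numbers; the nearest is compound 1, which gives 190 nM. Compound 3 `O=C(Nc1ccc(Oc2ccnc3[nH]ccc23)c(F)c1)c1cc2cccnc2n(-c2ccc(Br)cc2)c1=O` differs from compound 2 by bromo in place of fluoro on an aromatic carbon. Among the measured compounds shown here, the only measured step, a 3.1-fold lower number from compound 1 to compound 2 (0.49 log units; beyond the scatter), exchanges hydrogen for fluoro rather than one halogen for another, so it bears on this change only loosely. For the measured compounds named here, no measured pair trades fluoro for bromo. The expected step is therefore one within the scatter, a 1.1-fold lower number from compound 2 to compound 3 (0.05 log units; within the scatter). Compound 3 is expected to give 55 nM, with a range of 20 nM to 160 nM.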

Compound 3, half-maximal inhibitory concentration: 210 nM
Beside the measured number, compound 3's estimate is 3.8-fold (0.58 log units) below it; measured number outside the range, above it.
By their numbers in this assay, from the lowest: compound 2; then compounds 1 and 3 (each within the scatter of the next).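

In this assay the halogens at this position are not interchangeable: 4-fluorophenyl to 4-bromophenyl gives a 3.4-fold higher number from compound 2 to compound 3 (0.53 log units; beyond the scatter) and so the gain seen with fluoro does not carry over to bromo. Set against hydrogen, bromo gives a 1.1-fold higher number from compound 1 to compound 3 (0.04 log units; within the scatter) and compound 3 thus sits level with compound 1 within the scatter. Nothing available accounts for the difference between the two halogens.

The compounds shown leave open how chloro, methyl, methoxy or an amine would read at this position. From the compounds shown here alone, whether fluoro gives the same gain on the other carbons of this ring also stays open.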